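The compounds below may be only part of what the source reports. "The series", "measured", "known", "first", "only" and "open" are said of these compounds alone.

Measured compounds:
- compound 1, `O=C(CN1CCN(c2cccc(F)c2)CC1)Nc1nc2c(s1)CCCC2`: "not determined" (no result reported)
- compound 2, `O=C(CN1CCN(c2ccc(F)cc2)CC1)Nc1nc2ccccc2s1`: 4.4
- compound 3, `Cc1nc(NC(=O)CN2CCN(c3ccc(F)cc3)CC2)sc1C`: 3.7

Working notes on the series. In a physicochemical assay for lipophilicity, in phosphate buffer, measured as octanol-water partition, at pH 7.4 (a lower number here means a more polar compound, a higher number a more lipophilic compound), compound 2 gives 4.4 and compound 3 gives 3.7; these two share the amide-linked piperazine bearing the 4-fluorophenyl group and differ in the core, and the two numbers lie apart by more than the usual scatter, with compound 3 the more polar of the pair. For compound 1 no result is reported in this assay, so compound 1 stands on no number of its own; its core and its 3-fluorophenyl group place it close to compound 2 by structure, nothing more can be said of it from the data.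

Compound 4, `O=C(CN1CCN(c2cccnc2)CC1)Nc1nc2c(s1)CCCC2`, is the next compound to be measured in this assay. It differs from compound 1 as follows: pyridin-3-yl in place of 3-fluorophenyl on an amine nitrogen in a ring. With no measured pair of this kind in the series, the expectation can rest only on the change itself. The step in this assay is expected to go downward, toward the more polar side, and by more than the scatter. For compound 4 the expected distribution coefficient is 3, with a range from 2.3 to 3.7.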

Compound 4, distribution coefficient: 3.3
Compound 4: middle estimate off by 0.30 log units, on the low side; low and high end bracket the measured number.
By their numbers in this assay, from the lowest: compound 4; then compound 3; then compound 2.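

No new step can be read from compound 4: compound 1, its one-place partner, has no number in this assay and compound 2 and compound 3 differ from compound 4 in more than one place. As far as these compounds go, the size of the change from 3-fluorophenyl to pyridin-3-yl on the shared scaffold stays open. Nothing available bears on the reason for the result of compound 4.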